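Aryl change on the urea nitrogen: working notes

The compounds below may be only part of what the source reports. "The series", "measured", "known", "first", "only" and "open" are said of these compounds alone.

Measured compounds in a functional assay on NCI-H226 cells (Homo sapiens) for inhibition, read by sulforhodamine B assay, with a stated time of 48 h; a higher number here means a weaker inhibitor of growth, a lower number a stronger inhibitor of growth:
compound 1 `COc1cc(-c2nn(-c3cccc(NC(=O)c4cccc(C(F)(F)F)c4)c3)cc2-c2ccncc2)ccc1Cl` gives 1660 nM
compound 2 `COc1cc(-c2nn(-c3cccc(NC(=O)Nc4ccc(Cl)c(Cl)c4)c3)cc2-c2ccncc2)ccc1Cl` gives 1350 nM

Compound 2 holds the lowest of the two numbers in this assay; the nearest is compound 1, and the step of a 1.2-fold lower number from compound 1 to compound 2 (0.09 log units; within the scatter) lies within the scatter. Compound 3 `COc1cc(-c2nn(-c3cccc(NC(=O)Nc4cccc(C(F)(F)F)c4)c3)cc2-c2ccncc2)ccc1Cl` is not yet measured. It differs from compound 2 by 3-(trifluoromethyl)phenyl in place of 3,4-dichlorophenyl on an amide-type nitrogen. Within the data shown here, the only measured step, a 1.2-fold lower number from compound 1 to compound 2 (0.09 log units; within the scatter), alters both the group and the link to the carbonyl at once, so no step isolates the aryl swap on its own. That step was within the scatter, and the 3-(trifluoromethyl)phenyl group on the amide of compound 1 gave 1660 nM. The expectation for compound 3 is therefore a step of a 1.1-fold higher number from compound 2 to compound 3 (0.05 log units; within the scatter) in this assay, not beyond the scatter. Compound 3 is estimated at 1500 nM. The expected range for compound 3 runs from 700 nM to 3200 nM.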

Compound 3, concentration for 50% growth inhibition: 1380 nM
For compound 3 the middle estimate is 1.1-fold (0.04 log units) above the measured one; the measured number falls inside the stated range.
By their numbers in this assay, from the lowest: compounds 2, 3 and 1 (each within the scatter of the next).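

In this assay, among these compounds, the aryl swap on the urea nitrogen, which no earlier step isolated, gives a 1.0-fold higher number from compound 2 to compound 3 (0.01 log units; within the scatter), so 3-(trifluoromethyl)phenyl and 3,4-dichlorophenyl cannot be told apart at this place. The link can now be read alone as well: with the 3-(trifluoromethyl)phenyl group held constant, the change to (3-(trifluoromethyl)phenyl)amino gives a 1.2-fold lower number from compound 1 to compound 3 (0.08 log units; within the scatter), so the amide and urea forms also cannot be separated in this assay. No supporting measurement bears on why these values stay so close.

On these data alone, all three compounds carry a halogen-bearing phenyl group, so the tolerance of this place for other kinds of group remains open. A cyclohexyl group, a phenyl carrying a carboxylic acid or a phenyl carrying a dimethylamino group on the amide-type nitrogen would test whether the same level persists.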